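Swapping Methoxy for Nitro: Expected Cytotoxicity of Compound 4

The source may report more compounds than this note shows. Statements on the series, on what has been measured and on what is new or still open speak of the compounds shown alone.

Measured compounds:
- Compound 1, `CC(=O)OC[C@H]1O[C@H](OC[C@@H](Cn2cc(CN(c3nc(-c4ccc([N+](=O)[O-])cc4)no3)C3CCCCC3)nn2)OC(C)=O)C=C[C@@H]1OC(C)=O`, gives > 200 ug/mL in an ADME assay on HepG2 cells (Homo sapiens) for cytotoxicity, read by MTT assay, with a stated time of 48 h; on this read-out higher numbers stand for lower toxicity in this test and lower numbers for higher toxicity in this test; this is a limit of the assay, not a number.
- Compound 2, `C#CCN(c1nc(-c2ccc(OC)cc2)no1)C1CCCCC1`, gives 72.5 ug/mL in this assay.
- Compound 3, `COc1ccc(-c2noc(N(Cc3cn(C[C@H](CO[C@@H]4C=C[C@H](OC(C)=O)[C@@H](COC(C)=O)O4)OC(C)=O)nn3)C3CCCCC3)n2)cc1`, gives 141 ug/mL in this assay.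

Compound 2 and compound 3 sit within the usual scatter of each other, so their two numbers show no real gap. The difference between the core of compound 2 and the core of compound 3 is not broken down here.

Compound 4, `C#CCN(c1nc(-c2ccc([N+](=O)[O-])cc2)no1)C1CCCCC1`, has not yet been measured in this assay. It differs from compound 2 by one change: nitro in place of methoxy on an aromatic carbon. The same change, at a place described in the same words, turns compound 3 into compound 1: nitro in place of methoxy on an aromatic carbon. For that measured pair the step was an at least 1.4-fold higher number from compound 3 to compound 1 (0.15 log units; that floor lies within the scatter). Its true size is not known because of the limit of > 200 ug/mL in this assay, at which 1 of the 3 values shown sits, so the number for compound 1 is only bounded from below.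

Carried over to compound 2, the same change is expected to move the number in the same direction and by a similar modest amount, giving an estimated step of a 1.4-fold higher number from compound 2 to compound 4 (0.16 log units; within the scatter). This rests on compound 3 to compound 1 alone, a single example with a bounded end. Compound 4 is therefore expected to show about 105 ug/mL in this assay, with a plausible range from 50 ug/mL to 200 ug/mL.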

Compound 4, half-maximal cytotoxic concentration: 43.7 ug/mL
Estimate against measurement, compound 4: 2.4-fold (0.38 log units) above, and the stated range ends above it.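

On the core of compound 2, putting nitro in place of methoxy on an aromatic carbon gives a 1.7-fold lower number from compound 2 to compound 4 (0.22 log units; within the scatter), so in this assay this pair shows no real gap between the two groups. Setting this pair beside the one on the larger core shows neither that the change behaves alike on both cores nor that it behaves differently: the same change on two cores in this assay, an at least 1.4-fold higher number (0.15 log units; that floor lies within the scatter) from compound 3 to compound 1 and a 1.7-fold lower number (0.22 log units; within the scatter) from compound 2 to compound 4; the limit leaves it open whether they differ Compound 1 gives > 200 ug/mL, which is a limit of the assay and not a number, so the true size of the step into compound 1 stays unknown, and two pairs, one of them open-ended, give no rule for carrying this change to another core.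

The compounds shown leave open how a different group, such as an amine, a carboxylic acid or a nitrile, would read on the same aromatic carbon, since methoxy and nitro are the only two groups compared there. They also leave open what the change would do on a third core, and a number for the nitro compound on the larger core that falls inside the range of the assay would be needed to compare the two steps directly.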